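Amide change carried from the furan to the thiophene analogue

The compounds below may be only part of what the source reports. "The series", "measured", "known", "first", "only" and "open" are said of these compounds alone.

Compound 1 `CC1=C(C(=O)NC(C)C)C(c2ccco2)NC(=O)N1` gives 4% in an assay on membranes from HeLa cells for displacement of a labelled ligand from adenosine receptor A3 (Homo sapiens), read by scintillation counting, with a stated time of 180 min, tested at 1 uM; on this read-out higher numbers stand for more inhibition at the one concentration tested (going by the name of the read-out) and lower numbers for less inhibition. Compound 2 `CCN(CC)C(=O)C1=C(C)NC(=O)NC1c1ccco1` differs from compound 1 by diethylamino in place of isopropylamino on a carbonyl carbon; in this assay compound 2 gives 19%, which is a number 15 percentage points higher from compound 1 to compound 2 (beyond the scatter). Compound 3 `CC1=C(C(=O)NC(C)C)C(c2cccs2)NC(=O)N1` differs from compound 1 by thiophen-2-yl in place of furan-2-yl on a saturated ring carbon; in this assay compound 3 gives 1%, and the step is a number 3 percentage points lower from compound 1 to compound 3 (within the scatter). Among the three measured compounds, compound 2 shows the highest reading, while compound 1 and compound 3 sit within the scatter of each other.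

Compound 4 `CCN(CC)C(=O)C1=C(C)NC(=O)NC1c1cccs1` has not been measured in this assay. It differs from compound 3 by diethylamino in place of isopropylamino on a carbonyl carbon. For the measured compounds named here, this is the same change as the one from compound 1 to compound 2, made at a carbonyl carbon whose other neighbour is the same double-bonded ring carbon in both cases; the two starting cores differ only in the way described for compound 3 against compound 1. Going by the values given here, only one earlier instance of this change is known, so any transfer rests on a single step.

The step from compound 3 to compound 4 is expected to be about a number 13 percentage points higher from compound 3 to compound 4 (beyond the scatter) in this assay, close to a number 15 percentage points higher from compound 1 to compound 2 (beyond the scatter), because compound 3 starts at 1% and leaves room for a rise of that size. Compound 4 is accordingly estimated at 14% in this assay, with a plausible range from 0% to 30%.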

Compound 4, a percentage reported as inhibition, at one concentration (the size of the read-out at that concentration, not a potency): 31%
Estimate against measurement, compound 4: 17 percentage points below, and the stated range ends below it.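

In this assay, diethylamino in place of isopropylamino also raises the reading on the thiophen-2-yl core, a number 30 percentage points higher from compound 3 to compound 4 (beyond the scatter), so the direction of the change carries over from the furan-2-yl core but its size does not: the same change on two cores in this assay, a number 15 percentage points higher (beyond the scatter) from compound 1 to compound 2 and a number 30 percentage points higher (beyond the scatter) from compound 3 to compound 4, 15 percentage points apart, beyond the scatter of two such steps Seen from the other side of the same four compounds, thiophen-2-yl in place of furan-2-yl also depends on the amide it is paired with, giving a number 12 percentage points higher from compound 2 to compound 4 (beyond the scatter) with diethylamino, whereas with isopropylamino the step is a number 3 percentage points lower from compound 1 to compound 3 (within the scatter): the same change on two cores in this assay, a number 3 percentage points lower (within the scatter) from compound 1 to compound 3 and a number 12 percentage points higher (beyond the scatter) from compound 2 to compound 4, 15 percentage points apart, beyond the scatter of two such steps The two changes therefore do not simply add within this set, but two pairs of compounds read at one concentration give no potency, no cause for the difference and no rule for any other core.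

Still open, from the compounds shown here alone, is whether the rise holds for other amines on the same carbonyl carbon, such as dimethylamino, dipropylamino or piperidine. Also open, going by these compounds, is whether a phenyl group on the saturated ring carbon would show the same dependence on the amide as the furan-2-yl and thiophen-2-yl compounds.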